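Swapping Fluoro for Methoxy on the Aryl Ring

The source may report more compounds than this note shows. Statements on the series, on what has been measured and on what is new or still open speak of the compounds shown alone.

Compound 3 `C=CC1=C(C(=O)Nc2ccc(C)cc2)C(c2ccc(F)cc2)OC1` gives 59200 nM in a functional assay on QGY7701 cells (Homo sapiens) for cytotoxicity, read by MTT assay, with a stated time of 24 h; a lower number here means a stronger inhibitor, a higher number a weaker inhibitor. It stands alongside compound 2 `C=CC1=C(C(=O)NCc2ccc(Cl)cc2)C(c2ccc(F)cc2)OC1`, which gives 36900 nM in this assay; the step of a 1.6-fold higher number from compound 2 to compound 3 (0.21 log units; within the scatter) lies within the scatter, so the two cannot be told apart. Compound 1 `C=CC1=C(C(=O)NCCC)C(c2ccc(F)cc2)OC1` reaches only the limit > 100000 nM in this assay. Compound 4 `C=CC1=C(C(=O)Nc2ccc(C)cc2)C(c2ccc(OC)cc2)OC1` differs from compound 3 by methoxy in place of fluoro on an aromatic carbon. The measured steps of an at least 2.7-fold lower number from compound 1 to compound 2 (0.43 log units; beyond the scatter) and an at least 1.6-fold lower number from compound 1 to compound 3 (0.22 log units; that floor lies within the scatter) touch the amide side only, and none alters the ring where methoxy now enters, so they offer no guide to this move. For compound 4 no step beyond the scatter is expected: a 1.0-fold higher number from compound 3 to compound 4 (0.01 log units; within the scatter). Compound 4 is estimated at 60000 nM, between 20000 nM and 150000 nM.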

Compound 4, half-maximal inhibitory concentration: > 100000 nM
Compound 4: a limit, no number (the forecaster's own chance of this, stated with the estimate: 30%); middle value at least 1.6-fold (0.22 log units) from the limit.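

Within the data shown here, compound 4 gives the first look at a change on the aromatic ring that carries fluoro in compound 3, with the amide side left as it was, and methoxy brings no gain in this assay: the reading is an at least 1.6-fold higher number from compound 3 to compound 4 (0.22 log units; that floor lies within the scatter). The result for compound 4 is a limit, so this step gives only a floor and does not establish a real loss: the limit of > 100000 nM in this assay, at which 2 of the 4 values shown sit.

On these data alone, whether methoxy would behave the same way alongside the 4-chlorobenzyl amide of compound 2 stays open. So does the effect of a hydroxyl, an amine or a chloro group in place of fluoro.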